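Dropping the Fluoro and Changing the Link in Compound 4

This account rests on a few compounds, and the source may have more. Where it says the series, first, only, none or still open, it means among the compounds named here.

Three measured compounds share one core and differ only in a halogen on the benzothiazole part. In a physicochemical assay, read by spectrophotometry, with a stated time of 10 min (a lower number here means a stronger inhibitor, a higher number a weaker inhibitor), compound 1 `O=c1cc(-c2ccccc2)oc2cc(OCCCCNc3nc4ccc(Cl)cc4s3)cc(O)c12` gives 4.16 ug/mL. In this assay compound 2 `O=c1cc(-c2ccccc2)oc2cc(OCCCCNc3nc4ccc(Br)cc4s3)cc(O)c12` gives 6.57 ug/mL, and compound 3 `O=c1cc(-c2ccccc2)oc2cc(OCCCCNc3nc4ccc(F)cc4s3)cc(O)c12` gives 5.25 ug/mL. Compound 3 therefore holds the second highest of the three numbers, but the steps of a 1.3-fold higher number from compound 1 to compound 3 (0.10 log units; within the scatter) and a 1.3-fold lower number from compound 2 to compound 3 (0.10 log units; within the scatter) both stay within the scatter, as does a 1.6-fold higher number from compound 1 to compound 2 (0.20 log units; within the scatter), so the three cannot be told apart.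

Compound 4 `O=c1cc(-c2ccccc2)oc2cc(OCCCCNNc3nc4ccccc4s3)cc(O)c12` has not been measured. Its change from compound 3 is (1,3-benzothiazol-2-yl)amino in place of 6-fluoro-1,3-benzothiazol-2-yl on an amine nitrogen; cut one bond further out, the fluoro is gone and the link to the chain is altered. Among the compounds with values here, none of the measured steps tests either part of this change; they only show that swapping one halogen for another leaves the number where it was. The expectation is therefore no step beyond the scatter, with wide uncertainty, a 1.2-fold higher number from compound 3 to compound 4 (0.09 log units; within the scatter). Compound 4 is estimated at 6.5 ug/mL, between 3 ug/mL and 14 ug/mL.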

Compound 4, half-maximal inhibitory concentration: 8.73 ug/mL
For compound 4 the middle estimate is 1.3-fold (0.13 log units) below the measured one; the measured number falls inside the stated range.
By their numbers in this assay, from the lowest: compounds 1, 3, 2 and 4 (each within the scatter of the next, the first and the last beyond it).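

In this assay the change to (1,3-benzothiazol-2-yl)amino on the amine nitrogen gives a 1.7-fold higher number from compound 3 to compound 4 (0.22 log units; within the scatter) and a 1.3-fold higher number from compound 2 to compound 4 (0.12 log units; within the scatter) so compound 4 cannot be told apart from either the fluoro or the bromo compound. Measured against the chloro compound, the same change gives a 2.1-fold higher number from compound 1 to compound 4 (0.32 log units; beyond the scatter) which is a modest step, yet the only one so far that lies beyond the scatter, so this position tolerates the change with at most a small loss. Nothing available explains this step.

This change removes the halogen and alters the link together, so the step cannot be assigned to either part alone, and a plain 1,3-benzothiazol-2-yl group on the amine nitrogen would separate them. Also open, going by these compounds, is how a methoxy group in place of the halogen, or a longer chain, would read.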